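Dimethoxyphenyl to cyanophenyl on the sulfonyl sulfur

The compounds below may be only part of what the source reports. "The series", "measured", "known", "first", "only" and "open" are said of these compounds alone.

Compound 1 `CC1CCN(c2c(S(=O)(=O)c3ccc(Cl)c(Cl)c3)cnc3ccc(Cl)cc23)CC1` and compound 2 `COc1ccc(S(=O)(=O)c2cnc3ccc(Cl)cc3c2N2CCC(C)CC2)cc1OC` share one core and differ only in the aryl group on the sulfonyl sulfur. In an assay on isolated protein for displacement of a labelled ligand from metabotropic glutamate receptor 5 (Homo sapiens), with a stated time of 60 min, tested at 1 uM (on this read-out lower numbers stand for less inhibition and higher numbers for more inhibition at the one concentration tested (going by the name of the read-out)), compound 1 gives 86%, and compound 2 gives 61%. The change a number 25 percentage points lower from compound 1 to compound 2 (beyond the scatter) is a modest loss beyond the scatter, and on these two numbers compound 2 stands lowest, with compound 1 the nearer and higher of the pair.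

Compound 3 `CC1CCN(c2c(S(=O)(=O)c3cccc(C#N)c3)cnc3ccc(Cl)cc23)CC1` is the next step from compound 2: 3-cyanophenyl in place of 3,4-dimethoxyphenyl on a sulfonyl sulfur. Among the compounds with values here, no measured step pairs a cyanophenyl with either group already seen, so the only guide is a number 25 percentage points lower from compound 1 to compound 2 (beyond the scatter), which was modest. On that guide compound 3 is expected to land somewhere between the two measured numbers, nearer the middle than either end. The estimated step, a number 11 percentage points higher from compound 2 to compound 3 (beyond the scatter), is a small gain that need not exceed the scatter. In this assay compound 3 is therefore estimated at 72%, within a range from 50% to 90%.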

Compound 3, a percentage reported as inhibition, at one concentration (the size of the read-out at that concentration, not a potency): 90%
Compound 3: the middle estimate sits 18 percentage points below what was measured; the measured number falls inside the stated range.
By their numbers in this assay, from the lowest: compound 2; then compounds 1 and 3 (each within the scatter of the next).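

The step of a number 29 percentage points higher from compound 2 to compound 3 (beyond the scatter), read in this assay, shows that the loss seen with the 3,4-dimethoxyphenyl group is recovered by a smaller aryl group on the sulfonyl sulfur, one with no chlorine on it. Set against the 3,4-dichlorophenyl group, the 3-cyanophenyl group gives a number 4 percentage points higher from compound 1 to compound 3 (within the scatter), so chlorine atoms on this aryl group are not needed for a high reading at this position, and compound 2 alone stands apart among the three. Nothing at hand explains why the 3,4-dimethoxyphenyl group reads differently from the other two aryl groups.

On these data alone, with one tested concentration and values within the scatter of each other, compound 1 and compound 3 cannot be put in order, and whether their potencies differ stays open. As far as these compounds go, it also stays open how a plain phenyl, a phenyl carrying a single methoxy group, or a phenyl carrying a carboxylic acid would read on this sulfonyl sulfur, and so whether one methoxy group is enough to bring the reading down.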